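Ethoxy to methoxy on a quinone core: an expected step

This account rests on a few compounds, and the source may have more. Where it says the series, first, only, none or still open, it means among the compounds named here.

Measured compounds:
compound 1, `CCOc1cc(C)c(Cl)c2c1C(=O)C=CC2=O`, 44200 nM
compound 2, `CCOc1cc(C)cc2c1C(=O)C=CC2=O`, 25300 nM
compound 3, `COc1c(C)cc(Cl)c2c1C(=O)C=CC2=O`, 44900 nM

In a functional assay on SNO cells (Homo sapiens) for cytotoxicity, read by XTT assay, with a stated time of 24 h (on this read-out lower numbers stand for stronger inhibition and higher numbers for weaker inhibition), compound 2 sits at the low end of the three numbers, but compound 1 and compound 3 both lie within the scatter of it. Within the data shown here, the one single-point step among the measured compounds, a 1.7-fold lower number from compound 1 to compound 2 (0.24 log units; within the scatter), concerns the chloro group and does not touch the alkoxy chain. Compound 4, `COc1cc(C)cc2c1C(=O)C=CC2=O`, differs from compound 2 by hydrogen in place of methyl on a saturated chain carbon bound to an oxygen on an aromatic ring. Compound 3 carries a methoxy group as well, yet it differs from compound 2 in more than one place, so its number and that of compound 2 show only that both fall within the scatter of each other. Nothing measured here bears directly on shortening ethoxy to methoxy, and the three numbers are all close. The step expected in this assay from compound 2 is therefore a 1.2-fold higher number from compound 2 to compound 4 (0.07 log units; within the scatter), none beyond the scatter. Compound 4 is expected to give about 30000 nM, between 12000 nM and 75000 nM.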

Compound 4, half-maximal inhibitory concentration: 22500 nM
Estimate against measurement, compound 4: 1.3-fold (0.12 log units) above; the range from low to high includes it.
By their numbers in this assay, from the lowest: compounds 4, 2, 1 and 3 (each within the scatter of the next).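

In this assay, among these compounds, the change from ethoxy to methoxy gives a 1.1-fold lower number from compound 2 to compound 4 (0.05 log units; within the scatter) and so provides the first direct reading at this place, on a saturated chain carbon bound to an oxygen on an aromatic ring. The earlier single-point step, a 1.7-fold lower number from compound 1 to compound 2 (0.24 log units; within the scatter), concerned only the chloro group, whereas this pair shows that taking the methyl off the alkoxy chain also leaves the number within the scatter. Nothing available here accounts for this result.

From the compounds shown here alone, whether a longer chain such as propoxy, or a hydroxyl or an amine in place of the alkoxy group, would move the number beyond the scatter remains open. So does the outcome of the same change from ethoxy to methoxy on compound 1, which carries the chloro group.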